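Isobutyl in place of isopropylamino on the shared core

This account rests on a few compounds, and the source may have more. Where it says the series, first, only, none or still open, it means among the compounds named here.

Compound 2 `CC(C)NC1=NS(=O)(=O)c2cc(Cl)ccc2N1` and compound 1 `CC(C)OC1=NS(=O)(=O)c2cc(Cl)ccc2N1` share one core. In a functional assay on the whole organism (uterus, Rattus norvegicus, strain Wistar) for inhibition, tested at 100 uM (a lower number here means a stronger effect, a higher number a weaker effect of the compound at the concentration tested), compound 1 gives 68.7%; compound 2 gives 75.6%, and the two values lie within the scatter of each other, as the step of a number 6.9 percentage points higher from compound 1 to compound 2 (within the scatter) shows. Compound 3 `CC(C)CC1=NS(=O)(=O)c2cc(Cl)ccc2N1` differs from compound 2 by isobutyl in place of isopropylamino on a carbon with a double bond to nitrogen. Going by the values given here, the only measured step exchanges an oxygen-linked for a nitrogen-linked group and stayed within the scatter; no measured step removes both donor and acceptor. Compound 3 is therefore expected to show no step beyond the scatter, estimated as a number 1.6 percentage points lower from compound 2 to compound 3 (within the scatter). Compound 3 is estimated at 74%, within 55% to 92%.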

Compound 3, a percentage reported as activity, at one concentration (the size of the read-out at that concentration, not a potency) in the Rattus norvegicus assay: 55%
Compound 3: middle estimate off by 19 percentage points, on the high side, within the range that was stated.
By their numbers in the Rattus norvegicus assay, from the lowest: compound 3; then compounds 1 and 2 (each within the scatter of the next).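

At this position, between two ring nitrogen atoms, a carbon-linked group separates from the oxygen- and nitrogen-linked ones in the Rattus norvegicus assay: isobutyl, with no hydrogen-bond donor or acceptor, gives a number 20.6 percentage points lower from compound 2 to compound 3 (beyond the scatter) and a number 13.7 percentage points lower from compound 1 to compound 3 (beyond the scatter), a stronger effect in both cases. In a physicochemical assay for acid dissociation, the same change also shifts the acid dissociation of the compound: the measured acid dissociation constant of compound 2, 9.51, and of compound 3, 8.52, a number 0.99 log units lower (beyond the scatter) In the physicochemical assay compound 2 gives 9.51 and compound 3 gives 8.52.

From the compounds shown here alone, whether this shift or the loss of donor and acceptor goes with the stronger effect stays open. A cyclopropyl group or a longer alkyl chain on this carbon would show whether the step holds beyond isobutyl.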